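The compounds below may be only part of what the source reports. "The series", "measured", "known", "first", "only" and "open" are said of these compounds alone.

Working notes on the series. Compound 1 `O=C(/C=C/c1coc2cc(O)ccc2c1=O)NCc1ccc(F)cc1` and compound 2 `COc1ccc(NC(=O)/C=C/c2coc3cc(O)ccc3c2=O)cc1` share one core and were both run through a functional assay (QGY7701 cells, Homo sapiens) for inhibition, read by MTT assay, with a stated time of 48 h; on this read-out lower numbers stand for stronger inhibition and higher numbers for weaker inhibition. In this assay compound 1 returns only a limit, > 100000 nM, and no number. In this assay compound 2 likewise returns only a limit, > 100000 nM, so compound 2 stands at the limit with no measured number to place it against the others. The step that the two limits leave unreadable from compound 1 to compound 2 is therefore of unknown size, since both ends fall on (the limit of > 100000 nM in this assay, at which 2 of the 2 values shown sit). Compound 3 `Cc1ccccc1NC(=O)/C=C/c1coc2cc(O)ccc2c1=O` carries 2-methylphenyl in place of 4-methoxyphenyl on an amide-type nitrogen. Going by the values given here, the only measured step touching the amide-type nitrogen gave no readable size, so no direction can be drawn from it. Compound 3 is expected, with the step that the limit leaves unreadable from compound 2 to compound 3, to remain at the limit of this assay rather than give a number. Compound 3 is estimated at 150000 nM, in a range from 40000 nM to 600000 nM.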

Compound 3, half-maximal inhibitory concentration: 9320 nM
Estimate against measurement, compound 3: 16-fold (1.21 log units) above, outside the stated range (below it).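

Changing the group on the amide-type nitrogen can bring a compound of this series off the limit in this assay: 2-methylphenyl in place of 4-methoxyphenyl gives an at least 10-fold lower number from compound 2 to compound 3 (1.03 log units; beyond the scatter). On the same nitrogen, 2-methylphenyl in place of 4-fluorobenzyl gives an at least 10-fold lower number from compound 1 to compound 3 (1.03 log units; beyond the scatter). Each of these steps starts from a limit, so its true size may be larger, and the step between the other two compounds cannot be read: the limit of > 100000 nM in this assay, at which 2 of the 3 values shown sit.

The compounds shown do not separate the contribution of the methyl group from that of the missing methoxy group or of the missing methylene link of the benzyl group. As far as these compounds go, how an unsubstituted phenyl on this nitrogen would read stays open, as does the effect of an amine or a carboxylic acid on the phenyl ring.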